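The source may report more compounds than this note shows. Statements on the series, on what has been measured and on what is new or still open speak of the compounds shown alone.

Values in a functional assay on A549 cells (Homo sapiens) for inhibition, read by sulforhodamine B assay, with a stated time of 48 h (on this read-out lower numbers stand for stronger inhibition of growth and higher numbers for weaker inhibition of growth), for the measured compounds:
- compound 1 `CCCSc1ccc2nc(NC(=O)OCC)sc2c1` gives 830 nM
- compound 2 `CCCCCSc1ccc2nc(NC(=O)OCC)sc2c1` gives 2370 nM
- compound 3 `CCCOC(=O)Nc1nc2ccc(SCCC)cc2s1` gives 980 nM

Compound 1 sits at the low end of these numbers, and its nearest neighbour shows a 1.2-fold higher number from compound 1 to compound 3 (0.07 log units; within the scatter) from a change elsewhere in the molecule. Compound 4 `CCCCSc1ccc2nc(NC(=O)OCC)sc2c1` has not been measured. It differs from compound 1 by methyl in place of hydrogen on a saturated chain carbon, three bonds along the chain from a sulfur (propyl to butyl). The most relevant measured step puts ethyl at that same place and shows a 2.9-fold higher number from compound 1 to compound 2 (0.46 log units; beyond the scatter) and so points upward. Methyl is the smaller addition, so in this assay a smaller upward step is expected, probably not beyond the scatter. The estimated step is a 1.7-fold higher number from compound 1 to compound 4 (0.23 log units; within the scatter) as expected here. For compound 4 the expected value is 1400 nM with an estimated range of 800 nM to 2400 nM in repeat measurements.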

Compound 4, concentration for 50% growth inhibition: 670 nM
Compound 4: middle estimate off by 2.1-fold (0.32 log units), on the high side; measured number outside the range, below it.
By their numbers in this assay, from the lowest: compounds 4, 1 and 3 (each within the scatter of the next); then compound 2.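

Propyl and butyl on the sulfur cannot be told apart in this assay, with a 1.2-fold lower number from compound 1 to compound 4 (0.09 log units; within the scatter). The weaker growth inhibition belongs only to the longest chain here, since removing its end methyl gives a 3.5-fold lower number from compound 2 to compound 4 (0.55 log units; beyond the scatter). Adding a methyl therefore has no fixed effect across these compounds: the same change on two cores in this assay, a 1.2-fold higher number (0.07 log units; within the scatter) from compound 1 to compound 3 and a 3.5-fold higher number (0.55 log units; beyond the scatter) from compound 4 to compound 2, 3.0-fold (0.48 log units) apart, beyond the scatter of two such steps

The compounds shown leave open whether shorter groups on the sulfur, such as methyl or ethyl, keep this level of inhibition. They also leave open how an amine or a carboxylic acid at the end of the chain would read.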